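Solubility of a furanylmethyl analogue of compound 2

The source may hold more compounds than are shown below. What is called first, only, known or untested is meant among the compounds shown, and "the series" means these compounds.

Measured so far:
compound 1 `COc1cccc(Oc2ccc3c(NCCCNCc4cc(F)ccc4OC)ccnc3c2)c1` gives 14500 nM
compound 2 `COc1ccc(F)cc1CNCCCNc1ccnc2cc(Cc3ccc(F)cc3)ccc12` gives 4200 nM
compound 3 `COc1ccc(F)cc1CNCCCNc1ccnc2cc(-c3cccc4ccccc34)ccc12` gives 32000 nM

All three numbers come from a physicochemical assay for solubility, with a stated time of 18 h, at pH 7.4; a lower number here means a less soluble compound, a higher number a more soluble compound. Compound 2 stands lowest of the three: compound 1 lies a 3.5-fold lower number from compound 1 to compound 2 (0.54 log units; beyond the scatter) away, and compound 3 lies a 7.6-fold higher number from compound 2 to compound 3 (0.88 log units; beyond the scatter) away, so compound 2 is the least soluble of the measured set.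

Compound 4 `Fc1ccc(Cc2ccc3c(NCCCNCc4ccco4)ccnc3c2)cc1` has not been measured. It differs from compound 2 in one place: furan-2-yl in place of 5-fluoro-2-methoxyphenyl on a saturated chain carbon bound to an amine nitrogen.

For the measured compounds named here, none of the measured steps touches this place. The steps of a 3.5-fold lower number from compound 1 to compound 2 (0.54 log units; beyond the scatter), a 2.2-fold higher number from compound 1 to compound 3 (0.34 log units; beyond the scatter) and a 7.6-fold higher number from compound 2 to compound 3 (0.88 log units; beyond the scatter) all change the group on an aromatic carbon of the shared core, while the change to compound 4 sits on a saturated chain carbon bound to an amine nitrogen. Going by the values given here, the measured steps therefore show only that swapping one aromatic group for another can move solubility modestly in either direction; they give no direct guide for this swap. A smaller aromatic group enters, so a small rise in this assay is expected, but not one clearly beyond the scatter.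

Compound 4 is thus expected to give 7000 nM, within 2500 nM to 20000 nM, which would be a step of a 1.7-fold higher number from compound 2 to compound 4 (0.22 log units; within the scatter).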

Compound 4, solubility: 4200 nM
Beside the measured number, compound 4's estimate is 1.7-fold (0.22 log units) above it, and the stated range covers the measured number.
By their numbers in this assay, from the lowest: compounds 2 and 4 (each within the scatter of the next); then compound 1; then compound 3.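

In this assay, putting furan-2-yl in place of 5-fluoro-2-methoxyphenyl on a saturated chain carbon bound to an amine nitrogen gives no change at the digits printed from compound 2 to compound 4 (within the scatter). For the compounds shown here, this is the first reading at this position, as every earlier step changed a group on an aromatic carbon of the shared core, and each of those steps lay beyond the scatter. Here, a six-membered aromatic ring of carbon only gives way to a five-membered aromatic ring with 1 hetero atom, and this one pair shows that such an exchange at this position need not shift the read-out, though nothing available explains why.

As far as these compounds go, this single pair rests on the 4-fluorobenzyl group of compound 2, so it remains open whether the same exchange would read alike with the naphthalen-1-yl group of compound 3 or the 3-methoxyphenoxy group of compound 1. Also open, from the compounds shown here alone, is how a group of a different kind on this chain carbon, such as a carboxylic acid, a morpholine or a plain cyclohexyl ring, would read in this assay.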